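The compounds below may be only part of what the source reports. "The series", "measured", "known", "first", "only" and "open" are said of these compounds alone.

In a functional assay on HT-29 cells (Homo sapiens) for cytotoxicity (a higher number here means a weaker inhibitor, a lower number a stronger inhibitor), compound 1 `COc1ccc(S(=O)(=O)N2CCc3cccc(NC(=O)c4cccs4)c32)cc1` gives 37 nM and compound 2 `COc1ccc(S(=O)(=O)N2CCc3cccc(NC(=O)c4ccc([N+](=O)[O-])cc4)c32)cc1` gives 65 nM. Within the data shown here, these two values lie within the scatter of each other, so compound 2 stands level with the only other measured compound. Compound 3 `COc1ccc(S(=O)(=O)N2CCc3cccc(NC(=O)c4ccc(F)cc4)c32)cc1` has fluoro in place of nitro on an aromatic carbon. Among the measured compounds shown here, the only measured step that bears on this, a 1.8-fold higher number from compound 1 to compound 2 (0.24 log units; within the scatter), replaced the group on the carbonyl carbon and stayed within the scatter. No step beyond the scatter is therefore expected in this assay. The expected change is a 1.3-fold lower number from compound 2 to compound 3 (0.11 log units; within the scatter). For compound 3 the estimated value is 50 nM, with an expected range of 18 nM to 150 nM.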

Compound 3, half-maximal inhibitory concentration: 55 nM
The estimate for compound 3 lay 1.1-fold (0.04 log units) below the measured number; the measured number falls inside the stated range.
By their numbers in this assay, from the lowest: compounds 1, 3 and 2 (each within the scatter of the next).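

In this assay, going from 4-nitrophenyl to 4-fluorophenyl gives a 1.2-fold lower number from compound 2 to compound 3 (0.07 log units; within the scatter) even though fluoro has 1 heavy atom against 3 for nitro, so two very different groups at this position read alike. Replacing thiophen-2-yl on the carbonyl carbon with 4-fluorophenyl gives a 1.5-fold higher number from compound 1 to compound 3 (0.17 log units; within the scatter) and leaves all three compounds level. No measurement at hand explains this flat result. Going by these compounds, whether an amine or a carboxylic acid at this position would also stay level remains open, as does whether any group here can move the number beyond the scatter.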